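Fluoro for methyl: working notes on one step

The compounds below may be only part of what the source reports. "The series", "measured", "known", "first", "only" and "open" are said of these compounds alone.

For the measured compounds named here, compound 1 `C=CCn1c(=O)/c(=C\c2cccc(C)c2)[nH]c(=O)/c1=C\c1ccccc1OC` is the only member of the series with a number in a functional assay on U-937 cells (Homo sapiens) for cytotoxicity, read by CCK-8 assay, with a stated time of 72 h; a lower number here means a stronger inhibitor, a higher number a weaker inhibitor: compound 1 gives 5100 nM. Compound 2 `COc1ccccc1/C=c1/[nH]c(=O)/c(=C\c2ccccc2OC)[nH]c1=O` was reported without a number in this assay, where compound 2 gives "not active" (no number reported). Compound 3 `C=CCn1c(=O)/c(=C\c2ccc(Cl)c(Cl)c2)[nH]c(=O)/c1=C\c1ccccc1` was reported the same way in this assay, where compound 3 gives "not active" (no number reported). Going by the values given here, no two measured compounds differ in one place only, so the size of a single change cannot be read from the measured pairs.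

Compound 4 `C=CCn1c(=O)/c(=C\c2cccc(F)c2)[nH]c(=O)/c1=C\c1ccccc1OC` is not yet measured. It differs from compound 1 by fluoro in place of methyl on an aromatic carbon. The change is confined to one aromatic carbon, and the step of a 1.2-fold higher number from compound 1 to compound 4 (0.07 log units; within the scatter) is expected to stay within the scatter, with no direction beyond it. Since compound 2 and compound 3 returned no number, some chance remains that compound 4 also returns none. For compound 4 the estimate is 6000 nM, with a range from 2500 nM to 15000 nM.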

Compound 4, half-maximal inhibitory concentration: 2500 nM
The estimate for compound 4 lay 2.4-fold (0.38 log units) above the measured number; the measured number falls inside the stated range.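

In this assay, for the compounds shown here, the change from 3-methylphenyl to 3-fluorophenyl gives the only readable one-place step, a 2.0-fold lower number from compound 1 to compound 4 (0.31 log units; beyond the scatter). This position, on an aromatic carbon meta to a large group, therefore responds to a modest degree: exchanging one heavy atom moves the number beyond the scatter, with no ring, hydrogen-bond donor, hydrogen-bond acceptor or net charge counted on either side. No measurement at hand accounts for this step.

Going by these compounds, it remains open whether an amine, a carboxylic acid or a longer alkyl chain at this position would move the number further, and in which direction. Steps involving compound 2 and compound 3 cannot be read, so the compounds shown do not tie the absence of a number to any single structural change.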